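Swapping an ortho amide for a nitrile on the triazole-bound ring

The compounds below may be only part of what the source reports. "The series", "measured", "known", "first", "only" and "open" are said of these compounds alone.

Measured so far:
compound 1 `COc1ccc(/C=C\C(=O)O)c(OCc2cn(-c3ccc(NC(C)=O)cc3)nn2)c1CC=C(C)C` gives 45700 nM
compound 2 `COc1ccc(/C=C\C(=O)O)c(OCc2cn(-c3cccc(C#N)c3)nn2)c1CC=C(C)C` gives 26500 nM
compound 3 `COc1ccc(/C=C\C(=O)O)c(OCc2cn(-c3ccccc3C(=O)N3CCC(O)C3)nn2)c1CC=C(C)C` gives "not determined" (no result reported) in a functional assay on NCI-H322 cells (Homo sapiens) for cytotoxicity, read by MTT assay, with a stated time of 24 h; on this read-out lower numbers stand for stronger inhibition and higher numbers for weaker inhibition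

Compounds 1, 2 and 3 share one core and differ only in the group on the aromatic nitrogen. Among the compounds with values here, the step of a 1.7-fold lower number from compound 1 to compound 2 (0.24 log units; within the scatter) is the only measured step, and it lies within the scatter. Compound 3 stands without a number, so it cannot be placed against compound 1 or compound 2. Compound 4 `COc1ccc(/C=C\C(=O)O)c(OCc2cn(-c3ccccc3C#N)nn2)c1CC=C(C)C` arises from compound 3 by the change (cyano in place of (3-hydroxypyrrolidin-1-yl)carbonyl on an aromatic carbon). Within the data shown here, no measured step bears on this change, so no direction can be expected; the cyano-bearing compound 2 is the nearest measured analogue. Compound 4 is estimated at 30000 nM, with a range of 10000 nM to 100000 nM.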

Compound 4, half-maximal inhibitory concentration: 14400 nM
Estimate against measurement, compound 4: 2.1-fold (0.32 log units) above, within the range that was stated.
By their numbers in this assay, from the lowest: compounds 4, 2 and 1 (each within the scatter of the next, the first and the last beyond it).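

In this assay, shifting the nitrile on the ring (a 1.8-fold lower number from compound 2 to compound 4 (0.26 log units; within the scatter)) leaves 2-cyanophenyl and 3-cyanophenyl indistinguishable. Within the data shown here, replacing 4-acetamidophenyl with 2-cyanophenyl (a 3.2-fold lower number from compound 1 to compound 4 (0.50 log units; beyond the scatter)) gives the first change at this position that clears the scatter, though the size of the effect is modest. Nothing measured here explains these results.

Steps to compound 3 cannot be read, as it has no number to compare. On these data alone, whether an amine or a carboxylic acid on this ring would lower the number further remains open.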